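One aromatic ring exchanged on a shared core

A few compounds are considered here, and "the series" means these few. Any claim that something is new, unique, unknown or untested is made for them only; others in the source may bear on it.

Of the compounds shown here, two with a shared core have been measured in an ADME assay on the whole organism (plasma) for pharmacokinetics, with Canis familiaris (Canis lupus familiaris) as the target, at a dose of 0.6 mg/kg by the oral route; a higher number here means more compound in the circulation at the dose given, a lower number less compound in the circulation. Compound 1 `Cc1ccc([C@H](C(=O)N(C)C)N2C(=O)[C@@H](C3Cc4ccccc4C3)NC(=O)[C@H]2CC(C)C)cn1` gives 454 ng.h/mL and compound 2 `CC[C@H](C)[C@@H]1C(=O)N[C@H](C2Cc3ccccc3C2)C(=O)N1[C@@H](C(=O)N(C)C)c1ccc(C)nc1C` gives 305 ng.h/mL, so the two stand within the usual scatter of each other. Compound 3 `CC[C@H](C)[C@@H]1C(=O)N[C@H](C2Cc3ccccc3C2)C(=O)N1[C@@H](C(=O)N(C)C)c1ccc(C)[n+]([O-])c1` differs from compound 2 at one place, on a saturated chain carbon bound to an amide-type nitrogen in a ring and a carbonyl carbon: a group of 8 heavy atoms (6 carbon, 1 nitrogen, 1 oxygen; one six-membered aromatic ring with 1 hetero atom) in place of a group of 8 heavy atoms (7 carbon, 1 nitrogen; one six-membered aromatic ring with 1 hetero atom), on a saturated chain carbon bound to an amide-type nitrogen in a ring and a carbonyl carbon. The 2,6-dimethylpyridin-3-yl group leaves, and the group that enters has no common name. Within the data shown here, no measured step shows what such an exchange does, so the expectation is weakly founded. A fall in this assay somewhat beyond the scatter is expected rather than a rise, although no change beyond the scatter remains possible. The estimated step is a 2.0-fold lower number from compound 2 to compound 3 (0.31 log units; beyond the scatter). For compound 3 the expected value is 150 ng.h/mL, with an estimated range from 40 ng.h/mL to 500 ng.h/mL.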

Compound 3, area under the concentration-time curve: 73 ng.h/mL
Compound 3: middle estimate off by 2.1-fold (0.31 log units), on the high side, within the range that was stated.
By their numbers in this assay, from the lowest: compound 3; then compounds 2 and 1 (each within the scatter of the next).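

In this assay, putting the entering group in place of 2,6-dimethylpyridin-3-yl on this saturated chain carbon gives a 4.2-fold lower number from compound 2 to compound 3 (0.62 log units; beyond the scatter) and this single step shows that the number can move beyond the scatter with a change at this place. The two groups have the same counts of heavy atoms, hydrogen-bond donors and hydrogen-bond acceptors, and each has one six-membered aromatic ring with 1 hetero atom and no net charge, so these counts alone do not account for the difference. Nothing measured here bears on why the number falls.

On these data alone, whether the same exchange would lower the number on the core of compound 1 remains open. So does the outcome at this place with a plain phenyl ring, or with an amine or a carboxylic acid on the ring.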